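The source may report more compounds than this note shows. Statements on the series, on what has been measured and on what is new or still open speak of the compounds shown alone.

Measured in a functional assay on the whole organism (strain Sprague-Dawley) for inhibition, with Rattus norvegicus as the target, with a stated time of 10 min; on this read-out higher numbers stand for an effect only at larger amounts of compound and lower numbers for an effect already at smaller amounts:
compound 1 `CCOC(=O)c1cnc(-c2ccccc2OCC)[nH]c1=O` gives 2 mg/kg
compound 2 `CCOC(=O)c1cnc(-c2ccccc2OC(C)C)[nH]c1=O` gives 2 mg/kg
compound 3 `CCCCOc1ccccc1-c1ncc(C(=O)OCC)c(=O)[nH]1` gives 0.5 mg/kg

Compound 3 has the lowest number of the three, and both other compounds lie beyond the scatter from it. Compound 4 `CCOC(=O)c1cnc(-c2ccccc2OC(C)CC)[nH]c1=O` carries sec-butyl in place of butyl on an oxygen on an aromatic ring. Within the data shown here, two measured steps bear on this change. Adding a methyl to the ethyl chain of compound 1 gave (no change at the digits printed from compound 1 to compound 2 (within the scatter)), whereas butyl in place of isopropyl gave (a 4.0-fold lower number from compound 2 to compound 3 (0.60 log units; beyond the scatter)). Sec-butyl has the four carbons of the butyl of compound 3 but is branched like the isopropyl of compound 2, so the data point both ways, and no branched four-carbon chain has been measured yet. A partial return towards compound 2 is therefore expected, a small rise in the number that may not clear the scatter (a 2.0-fold higher number from compound 3 to compound 4 (0.30 log units; within the scatter)). For compound 4 the estimated value is 1 mg/kg with an expected range of 0.3 mg/kg to 3 mg/kg in this series.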

Compound 4, dose for 50% inhibition: 0.5 mg/kg
Compound 4: the middle estimate sits 2.0-fold (0.30 log units) above what was measured; the measured number falls inside the stated range.
By their numbers in this assay, from the lowest: compounds 3 and 4 (each within the scatter of the next); then compounds 1 and 2 (each within the scatter of the next).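

In this assay, branching on the chain carbon bound to the oxygen carries no visible cost at this chain length: sec-butyl in place of butyl gave no change at the digits printed from compound 3 to compound 4 (within the scatter). The difference between isopropyl and butyl therefore does not read as a penalty for branching, since extending isopropyl to sec-butyl gave a 4.0-fold lower number from compound 2 to compound 4 (0.60 log units; beyond the scatter) and replacing a hydrogen of the ethyl chain with ethyl gave a 4.0-fold lower number from compound 1 to compound 4 (0.60 log units; beyond the scatter), leaving butyl and sec-butyl grouped apart from ethyl and isopropyl. Nothing available explains this grouping.

Still open, on these data alone, is whether a longer chain such as hexyl, or a cyclopentyl group, on this oxygen would lower the number further or raise it again. All the compounds shown also keep the ethyl ester, so the effect of a carboxylic acid or an amide at that place remains unknown.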